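A Methyl Relocated: From Compound 3 to Compound 4

This account rests on a few compounds, and the source may have more. Where it says the series, first, only, none or still open, it means among the compounds named here.

Compound 1 `Cc1ccc(-c2csc(NC(=O)COc3ccccc3C)n2)cc1` — 54400 nM
Compound 2 `Cc1ccccc1OCC(=O)Nc1nc(-c2ccc(Br)cc2)cs1` — 44900 nM
Compound 3 `Cc1ccccc1OCC(=O)Nc1nc(-c2ccc(Cl)cc2)cs1` — 62300 nM

All three compounds share one core and were measured in a functional assay on Ehrlich cells (Mus musculus) for cytotoxicity, read by MTT assay, with a stated time of 48 h; a lower number here means a stronger inhibitor, a higher number a weaker inhibitor. Compound 3 gives the highest of the three numbers, but the steps of a 1.1-fold higher number from compound 1 to compound 3 (0.06 log units; within the scatter) and a 1.4-fold higher number from compound 2 to compound 3 (0.14 log units; within the scatter) both lie within the scatter, so the three values cannot be told apart. The third step, a 1.2-fold lower number from compound 1 to compound 2 (0.08 log units; within the scatter), is also within the scatter.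

Compound 4 `Cc1ccc(OCC(=O)Nc2nc(-c3ccc(Cl)cc3)cs2)cc1` has not yet been measured. It differs from compound 3 by 4-methylphenyl in place of 2-methylphenyl on an oxygen on a saturated carbon. Among the compounds with values here, none of the measured steps touches this part of the molecule; each of them changes only the group on the other aromatic ring, and each stayed within the scatter. Within the data shown here, there is therefore no measured step that bears directly on this change, and the best guide is the general flatness of the series. The step from compound 3 to compound 4 is expected to be a 1.0-fold lower number from compound 3 to compound 4 (0.02 log units; within the scatter), that is, no change beyond the scatter. Compound 4 is estimated at 60000 nM, in the range 30000 nM to 120000 nM.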

Compound 4, half-maximal inhibitory concentration: 40600 nM
Beside the measured number, compound 4's estimate is 1.5-fold (0.17 log units) above it, within the range that was stated.
By their numbers in this assay, from the lowest: compounds 4, 2, 1 and 3 (each within the scatter of the next).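

Within the data shown here, this is the first measured change to the methylphenyl group on the oxygen, since the earlier steps altered only the group on the other aromatic ring. In this assay, exchanging 2-methylphenyl for 4-methylphenyl, with the same atoms joined differently, gives a 1.5-fold lower number from compound 3 to compound 4 (0.19 log units; within the scatter), so this change, like the earlier ones, does not move the number beyond the scatter. Nothing measured here bears on what lies behind this step.

The compounds shown leave open whether any group on this ring can move the number beyond the scatter, for instance an amine or a carboxylic acid in place of the methyl. They also leave open what a longer chain between the oxygen and the amide carbonyl would do.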